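Compound 3: thiophen-3-yl in place of phenyl

This account rests on a few compounds, and the source may have more. Where it says the series, first, only, none or still open, it means among the compounds named here.

Among the measured compounds shown here, in a functional assay on MCF7 cells (Homo sapiens) for inhibition, with a stated time of 72 h (a lower number here means a stronger inhibitor, a higher number a weaker inhibitor), compound 1 `NC1CCC(Nc2nc(NCc3ccc(-c4ccco4)cc3)c3ncn(C4CCCC4)c3n2)CC1` gives 85 nM and compound 2 `CC(C)(O)CNc1nc(NCc2ccc(-c3ccco3)cc2)c2ncn(C3CCCC3)c2n1` gives 15300 nM at the two ends of the three numbers so far. Compound 3 `NC1CCC(Nc2nc(NCc3ccc(-c4ccccc4)nc3)c3ncn(C4CCCC4)c3n2)CC1` gives 483 nM and stands second highest. Compound 4 `NC1CCC(Nc2nc(NCc3ccc(-c4ccsc4)nc3)c3ncn(C4CCCC4)c3n2)CC1` carries thiophen-3-yl in place of phenyl on an aromatic carbon and is otherwise the same as compound 3.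

The step of a 180-fold higher number from compound 1 to compound 2 (2.26 log units; beyond the scatter) is large but concerns the loss of the 4-aminocyclohexyl group, which compound 4 keeps, so it offers no guide here. The modest step of a 5.7-fold higher number from compound 1 to compound 3 (0.75 log units; beyond the scatter) bears more closely, with 6-phenylpyridin-3-yl in place of 4-(furan-2-yl)phenyl. For the measured compounds named here, it changes both rings at once, so no measured step isolates the outer ring. Compound 1 does hold a five-membered aromatic ring there, which gives a weak lean towards a lower number.

For compound 4 the estimated step is a 1.6-fold lower number from compound 3 to compound 4 (0.21 log units; within the scatter) and would be small, with no change beyond the scatter also possible. The expected value for compound 4 is 300 nM (estimated range 90 nM to 900 nM).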

Compound 4, half-maximal inhibitory concentration: 100 nM
The estimate for compound 4 lay 3.0-fold (0.48 log units) above the measured number; the range from low to high includes it.
By their numbers in this assay, from the lowest: compounds 1 and 4 (each within the scatter of the next); then compound 3; then compound 2.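

In this assay, among the compounds shown here, thiophen-3-yl in place of phenyl on an aromatic carbon gives a 4.8-fold lower number from compound 3 to compound 4 (0.68 log units; beyond the scatter), the first step that isolates the outer ring, and it shows that this ring alone moves the number beyond the scatter. With a 1.2-fold higher number from compound 1 to compound 4 (0.07 log units; within the scatter), 6-(thiophen-3-yl)pyridin-3-yl and 4-(furan-2-yl)phenyl cannot be told apart in this assay, so a pyridin-3-yl inner ring is compatible with a number level with that of compound 1 when the outer ring is thiophen-3-yl. No measurement at hand explains either step.

On these data alone, it remains open whether furan-2-yl or thiophen-2-yl on the same pyridin-3-yl group would match thiophen-3-yl. Also open, as far as these compounds go, is how a saturated ring such as piperidine, or an amine or carboxylic acid on the outer ring, would fare at this place.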